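The source may hold more compounds than are shown below. What is called first, only, known or untested is meant among the compounds shown, and "the series" means these compounds.

The study begins from two measured compounds. Compound 1 `Cc1ccc2nc(Nc3nc(Nc4ccc(S(N)(=O)=O)cc4)ncc3F)sc2c1` gives 1460 nM in a functional assay on HCT-116 cells (Homo sapiens) for antiproliferative activity, read by MTT assay, with a stated time of 48 h; on this read-out lower numbers stand for stronger inhibition and higher numbers for weaker inhibition. Compound 2 `Cc1cnc(Nc2ccc(C(C)C)cc2)nc1Nc1nc2ccccc2s1` reaches only a limit in this assay, reported as > 50000 nM, so no number is known for it; it sits at the limit of > 50000 nM in this assay, at which 1 of the 2 values shown sits. Compound 1 and compound 2 share a closely related core but differ in several places at once, so their two values show only that one is measurable and the other is not.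

The next compound, compound 3 `Cc1cnc(Nc2ccc(Cl)cc2)nc1Nc1nc2ccccc2s1`, is still unmeasured. It differs from compound 2 by chloro in place of isopropyl on an aromatic carbon. Among the compounds with values here, since compound 2 gives only a limit, no measured step can anchor the size of this change. The expectation is that the step from compound 2 to compound 3 remains small, an at least 1.4-fold lower number from compound 2 to compound 3 (0.15 log units; that floor lies within the scatter), with a fair chance that compound 3 also returns only a limit. Compound 3 is therefore estimated at 35000 nM, within a range from 8000 nM to 100000 nM.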

Compound 3, half-maximal inhibitory concentration: > 50000 nM
Compound 3 was reported as a limit (the forecaster's own chance of this, stated with the estimate: 50%); at least 1.4-fold (0.15 log units) between middle value and limit.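

Compound 2 and compound 3 both return only a limit in this assay, so the step between them cannot be read: the limit of > 50000 nM in this assay, at which 2 of the 3 values shown sit. The compounds shown leave open how chloro and isopropyl truly compare, and which of the several differences sets compound 1 apart from compound 2 and compound 3.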